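Aryl swap on a nucleoside series: thiophen-3-yl for phenyl

A few compounds are considered here, and "the series" means these few. Any claim that something is new, unique, unknown or untested is made for them only; others in the source may bear on it.

Compound 1 `COc1nc(N)nc2c1c(-c1ccccc1)cn2[C@@H]1O[C@H](CO)[C@@H](O)[C@H]1O` and compound 2 `COc1nc(N)nc2c1c(-c1ccsc1)cn2[C@@H]1O[C@H](CO)[C@@H](O)[C@H]1O` share one core; compound 3 `Nc1nc2c(c(-c3ccccc3)cn2[C@@H]2O[C@H](CO)[C@@H](O)[C@H]2O)c(=O)[nH]1` and the not yet measured compound 4 `Nc1nc2c(c(-c3ccsc3)cn2[C@@H]2O[C@H](CO)[C@@H](O)[C@H]2O)c(=O)[nH]1` share another. The difference between the two cores is not broken down here.

In a functional assay on HCT-116 cells (Homo sapiens), read by MTT assay, with a stated time of 72 h (a higher number here means a weaker inhibitor, a lower number a stronger inhibitor), compound 1 gives only a limit, > 20000 nM. Compound 2 likewise reaches only a limit in this assay, > 20000 nM. Compound 3 also stands at a limit in this assay, > 20000 nM. The change from compound 1 to compound 2 is thiophen-3-yl in place of phenyl on an aromatic carbon; the step that the two limits leave unreadable from compound 1 to compound 2 cannot be read from two limits. Within the data shown here, the sole evidence across the set is the limit of > 20000 nM in this assay, at which 3 of the 3 values shown sit.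

Compound 4 differs from compound 3 by thiophen-3-yl in place of phenyl on an aromatic carbon. Around the place, the change between compound 1 and compound 2 names the ring atom that bears a 3,4-dihydroxy-5-(hydroxymethyl)oxolan-2-yl group (9 heavy atoms), whereas the change from compound 3 to compound 4 names a ring atom that bears a group of 9 heavy atoms; it is the same kind of change, not the same.

The expected step that the limit leaves unreadable from compound 3 to compound 4 is taken as small, since compound 3 gives only the limit > 20000 nM. The step that the two limits leave unreadable from compound 1 to compound 2 gives no sign that this change moves the read-out. Compound 4 is therefore estimated at 35000 nM, with a range from 8000 nM to 150000 nM, most likely once more reported only as a limit.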

Compound 4, half-maximal inhibitory concentration: > 20000 nM
Compound 4: no number, only a limit (the forecaster's own chance of this, stated with the estimate: 80%); the middle value is on the limit's open side.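

In this assay compound 4 gives only a limit of > 20000 nM and no number, so the swap of thiophen-3-yl for phenyl yields no readable step from compound 3 to compound 4. The compounds shown leave open whether the aryl group or the core changes the read-out at all, because they offer a single result: the limit of > 20000 nM in this assay, at which 4 of the 4 values shown sit.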